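This account rests on a few compounds, and the source may have more. Where it says the series, first, only, none or still open, it means among the compounds named here.

Of the compounds shown here, two have been measured in a functional assay on cells (Melanoma cell, Homo sapiens) for cytotoxicity, read by sulforhodamine B assay, with a stated time of 48 h; on this read-out lower numbers stand for stronger inhibition of growth and higher numbers for weaker inhibition of growth. Compound 1 `COc1ccc(OC)c(-c2cc(-c3ccccc3)nn2-c2ccc(S(N)(=O)=O)cc2)c1` gives 15300 nM in this assay. Compound 2 `Oc1ccc(O)c(-c2cc(-c3ccccc3)nn2-c2ccccc2)c1` gives 22600 nM in this assay, and compound 1 is its only companion; the two numbers lie within the scatter of each other. Compound 3 `NS(=O)(=O)c1ccc(-n2nc(-c3ccccc3)cc2-c2cc(O)ccc2O)cc1` differs from compound 2 in one place: sulfamoyl in place of hydrogen on an aromatic carbon. Among the measured compounds shown here, no measured pair shows this change on its own, so nothing is known of its effect. The step expected from it, a 1.4-fold lower number from compound 2 to compound 3 (0.15 log units; within the scatter), is small and not clearly beyond the scatter. Compound 3 is estimated at 16000 nM, within 6000 nM to 40000 nM.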

Compound 3, concentration for 50% growth inhibition: 61900 nM
Compound 3: the middle estimate sits 3.9-fold (0.59 log units) below what was measured; the measured number lies above the stated range.
By their numbers in this assay, from the lowest: compounds 1 and 2 (each within the scatter of the next); then compound 3.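

In this assay, sulfamoyl in place of hydrogen, para to a large group, gives a 2.7-fold higher number from compound 2 to compound 3 (0.44 log units; beyond the scatter), so on this scaffold with 2,5-dihydroxyphenyl the change weakens growth inhibition. With sulfamoyl kept, 2,5-dihydroxyphenyl in place of 2,5-dimethoxyphenyl gives a 4.0-fold higher number from compound 1 to compound 3 (0.61 log units; beyond the scatter), so the result at this position depends on the group elsewhere on the core. No supporting evidence accounts for either step. The compounds shown leave open whether sulfamoyl would have the same effect alongside 2,5-dimethoxyphenyl. They also leave open how an amine or a carboxylic acid at this position would compare with hydrogen.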